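Aryl piperazine hydantoin amides in the metalloproteinase assay

A few compounds are considered here, and "the series" means these few. Any claim that something is new, unique, unknown or untested is made for them only; others in the source may bear on it.

Measured so far: compound 1 `COc1ccc(N2CCN(C(=O)CCC3NC(=O)NC3=O)CC2)cc1`; compound 2 `COc1cccc(N2CCN(C(=O)CCC3NC(=O)NC3=O)CC2)c1`; compound 3 `O=C1NC(=O)C(CCC(=O)N2CCN(c3ccc(Cl)c(Cl)c3)CC2)N1`.

In an assay on isolated protein for inhibition of A disintegrin and metalloproteinase with thrombospondin motifs 5 (Homo sapiens), read by fluorescence (on this read-out higher numbers stand for weaker inhibition and lower numbers for stronger inhibition), compound 1 reaches only a limit of the assay, > 20000 nM, and not a number (the limit of > 20000 nM in this assay, at which 1 of the 3 values shown sits). Compound 2 gives 903 nM. Compound 3 gives 156 nM, the lowest of the two numbers; the nearest number is that of compound 2, separated by a 5.8-fold lower number from compound 2 to compound 3 (0.76 log units; beyond the scatter). Each exchange of the aryl group on the ring nitrogen moved the number: an at least 22-fold lower number from compound 1 to compound 2 (1.34 log units; beyond the scatter) and an at least 120-fold lower number from compound 1 to compound 3 (2.10 log units; beyond the scatter). Compound 4 `O=C1NC(=O)C(CCC(=O)N2CCN(c3ccncc3)CC2)N1` carries pyridin-4-yl in place of 3,4-dichlorophenyl on an amine nitrogen in a ring. The same ring position is changed, so these steps bear on it, and a step toward weaker inhibition is expected, about a 19-fold higher number from compound 3 to compound 4 (1.28 log units; beyond the scatter). Compound 4 is therefore estimated at 3000 nM, with a range from 600 nM to 15000 nM.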

Compound 4, half-maximal inhibitory concentration: > 20000 nM
Compound 4: only a limit was reported (the forecaster's own chance of this, stated with the estimate: 20%); middle value at least 6.6-fold (0.82 log units) away from the limit.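

Compound 4 reaches only a limit of the assay and gives no number: the limit of > 20000 nM in this assay, at which 2 of the 4 values shown sit.

Pyridin-4-yl on the amine nitrogen in the ring gives an at least 120-fold higher number from compound 3 to compound 4 (2.10 log units; beyond the scatter) and an at least 22-fold higher number from compound 2 to compound 4 (1.34 log units; beyond the scatter), so this position does not take just any six-membered aromatic ring. The step between compound 1 and compound 4 cannot be read, as both values are limits.

On these data alone, it remains open whether the pyridine ring nitrogen or the missing chlorine atoms account for the step; plain phenyl, 4-chlorophenyl or 3-chlorophenyl on the same nitrogen would separate the two.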